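A Halogen Swap on the Shared Core

The source may hold more compounds than are shown below. What is called first, only, known or untested is meant among the compounds shown, and "the series" means these compounds.

Compound 1 `C=CCn1c(=O)/c(=C\c2cccc(Cl)c2)[nH]c(=O)/c1=C\c1ccccc1OC` is the starting point. In a functional assay on BGC-823 cells (Homo sapiens) for cytotoxicity, read by CCK-8 assay, with a stated time of 72 h (a higher number here means a weaker inhibitor, a lower number a stronger inhibitor), compound 1 gives 4600 nM. Compound 3 `C=CCn1c(=O)/c(=C\c2ccccc2C(F)(F)F)[nH]c(=O)/c1=C\c1ccccc1OC` carries 2-(trifluoromethyl)phenyl in place of 3-chlorophenyl on a double-bonded chain carbon bound to an aromatic carbon, and in this assay compound 3 gives 5100 nM; the step of a 1.1-fold higher number from compound 1 to compound 3 (0.04 log units; within the scatter). Going by the values given here, compound 2 `COc1ccccc1/C=c1/[nH]c(=O)/c(=C\c2cccc(Cl)c2Cl)[nH]c1=O` differs from compound 1 in more than one place, so no single step links them, and in this assay compound 2 is reported as "not active" (no number reported). Of the two compounds with numbers, compound 1 has the lower one, but its gap to compound 3 lies within the scatter, so neither can be called the stronger.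

Compound 4 `C=CCn1c(=O)/c(=C\c2ccc(F)c(Br)c2)[nH]c(=O)/c1=C\c1ccccc1OC` differs from compound 1 in one place: 3-bromo-4-fluorophenyl in place of 3-chlorophenyl on a double-bonded chain carbon bound to an aromatic carbon. Among the compounds with values here, the only measured step at this place, from compound 1 to compound 3, swapped one aryl group for a quite different one and still stayed within the scatter. Within the data shown here, no measured step here shows that a change at this place moves the number, so compound 4 is expected to land near compound 1, with the step of no change at the digits printed from compound 1 to compound 4 (within the scatter) expected to stay within the scatter. Compound 4 is estimated at 4600 nM in this assay, with a range from 2000 nM to 11000 nM.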

Compound 4, half-maximal inhibitory concentration: "not active" (no number reported)
No number was reported for compound 4; the estimate stays without a comparison.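

Compound 4 is reported in this assay as "not active" with no number, so no new step can be read between compound 1 and compound 4. Nothing available here explains this result. The compounds shown leave open how far a different aryl group at this place can move the number in this assay for this series.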